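Bromine in place of a methoxyphenyl group on the shared core

The compounds below may be only part of what the source reports. "The series", "measured", "known", "first", "only" and "open" are said of these compounds alone.

Three compounds have been measured in an ADME assay on HEL cells (Homo sapiens) for cytotoxicity, with a stated time of 3 days; a lower number here means that less compound is tolerated, a higher number that more compound is tolerated:
compound 1 `Cc1cc(-c2ccsc2)c2ncc(CSCCc3ccccc3)n2c1`: compound 1 gives > 50 ug/mL, which is a limit of the assay.
compound 2 `COc1cccc(-c2cc(C)c3ncc(CSCCc4ccccc4)n3c2)c1`: compound 2 gives 36 ug/mL.
compound 3 `COc1cccc(-c2cc(C)cn3c(CSCCc4ccccc4)cnc23)c1`: compound 3 gives > 50 ug/mL, which is a limit of the assay.

Among the measured compounds shown here, compound 2 stands as the only compound among the three with a number in this assay; the two others sit at the limit of > 50 ug/mL in this assay, at which 2 of the 3 values shown sit. For the measured compounds named here, the single step between compounds that differ in one place, a step that the two limits leave unreadable from compound 1 to compound 3, cannot be read, since one of its two ends is a limit.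

Compound 4 `Cc1cc(Br)cn2c(CSCCc3ccccc3)cnc12` is not yet measured. It differs from compound 2 by bromo in place of 3-methoxyphenyl on an aromatic carbon. Going by the values given here, no measured step bears on this change directly, so the expectation for compound 4 rests on the two limits and the one number in this assay. Compound 4 is expected to sit near the limit as well, with an estimated value of 45 ug/mL, ranging from 20 ug/mL to 100 ug/mL. The expected step of a 1.3-fold higher number from compound 2 to compound 4 (0.10 log units; within the scatter) is thus small, likely within the scatter, with a fair chance that only a limit is reported.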

Compound 4, half-maximal cytotoxic concentration: 28 ug/mL
For compound 4 the middle estimate is 1.6-fold (0.21 log units) above the measured one; measured number inside the range.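

Among the compounds shown here, the step of a 1.3-fold lower number from compound 2 to compound 4 (0.11 log units; within the scatter) is the first in this assay that can be read in size, since both of its ends are numbers, and it lies within the scatter. At this position, on an aromatic carbon two atoms from the ring nitrogen, the 3-methoxyphenyl can therefore give way to bromo, which brings no ring and no hydrogen-bond acceptor, with no readable difference in this read-out. The aryl group is thus not needed for the number seen with compound 2, at least in this one pair, and the two compounds cannot be told apart here, so the change offers no sign of tolerance being gained or lost.

Any step that ends at one of the other compounds stays unreadable, and these values give no size for such a comparison: the limit of > 50 ug/mL in this assay, at which 2 of the 4 values shown sit. Still open is whether the same holds for a group of another kind on this carbon, such as an amine or a carboxylic acid, and whether bromo would read the same on the shared core without the methyl group.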